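The source may hold more compounds than are shown below. What is called first, only, known or untested is meant among the compounds shown, and "the series" means these compounds.

Of the compounds shown here, two have so far been measured in a functional assay on MCF7 cells (Homo sapiens) for inhibition, with a stated time of 72 h; a higher number here means a weaker inhibitor of growth, a lower number a stronger inhibitor of growth. Compound 1 `N#Cc1cc(-c2nc3ccccc3s2)ccc1N` gives 580 nM in this assay, the highest of the two numbers. Compound 2 `C#Cc1cc(-c2nc3ccc(F)cc3s2)ccc1N` gives 110 nM in this assay, a number well below that of compound 1, a gap that lies beyond the usual scatter. Among the measured compounds shown here, the two compounds differ in more than one place, so no single step can be drawn between them; their values only show that compound 2 sits well below compound 1.

Compound 3 `N#Cc1cc(-c2nc3c(F)cccc3s2)ccc1N` has not yet been measured in this assay. It arises from compound 1 by fluoro in place of hydrogen on an aromatic carbon. For the measured compounds named here, no measured pair in this set shows the effect of this change on its own, so nothing can be said with confidence about the size of the step from compound 1 to compound 3. The only point of reference is that the fluorine-bearing compound 2 gives 110 nM while compound 1 gives 580 nM, but that comparison also carries a second change. The step from compound 1 to compound 3 is expected to be small, at most a modest lowering, as a 1.5-fold lower number from compound 1 to compound 3 (0.16 log units; within the scatter), though a result within the scatter is equally plausible. Compound 3 is estimated to give 400 nM in this assay, in a range from 150 nM to 1100 nM.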

Compound 3, concentration for 50% growth inhibition: 180 nM
Compound 3: middle estimate off by 2.2-fold (0.35 log units), on the high side, within the range that was stated.
By their numbers in this assay, from the lowest: compounds 2 and 3 (each within the scatter of the next); then compound 1.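

In this assay, among the compounds shown here, the replacement of hydrogen by fluoro gives a 3.2-fold lower number from compound 1 to compound 3 (0.51 log units; beyond the scatter) and is the first change in this set whose effect can be read on its own. It shows that this aromatic carbon of the six-membered aromatic ring of carbon only, ortho to a fused ring and meta to a fused ring, accepts a single fluoro group with a modest gain in growth inhibition and no loss, and that the step from this one heavy atom lies beyond the usual scatter. Nothing available here bears on why the number falls with this change.

Going by these compounds, whether the lowering is particular to fluoro or would also follow from chloro, methyl or methoxy on this same carbon remains open, as does whether fluoro on the other carbons of that ring would give a step of similar size. The compounds shown also leave open what ethynyl in place of nitrile does on its own, since the only compound carrying ethynyl differs from the others in more than one place.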